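Swapping cyclopropyl for oxan-4-yl on the shared core

The compounds below may be only part of what the source reports. "The series", "measured", "known", "first", "only" and "open" are said of these compounds alone.

- compound 1 `COc1cc2c(cn1)Oc1ccc(NC(=O)c3ccc(Cl)cn3)cc1[C@@]21COC(N)=N1`: 25 nm/s
- compound 2 `NC1=N[C@@]2(CO1)c1cc(NC(=O)c3ccc(Cl)cn3)ccc1Oc1cnc(C3CC3)cc12`: 29 nm/s

Both compounds were measured in an ADME assay on LLC-PK1 cells (Sus scrofa) for permeability, read by LC-MS, with a stated time of 2 h, tested at 5 uM; on this read-out lower numbers stand for lower permeability and higher numbers for higher permeability. Among the compounds with values here, with only two numbers available, compound 2 at 29 nm/s has a single neighbour, compound 1 at 25 nm/s, and the two lie within the usual scatter of each other, so neither can be ranked above the other.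

The next structure, compound 3 `NC1=N[C@@]2(CO1)c1cc(NC(=O)c3ccc(Cl)cn3)ccc1Oc1cnc(C3CCOCC3)cc12`, keeps the shared core and changes one group: oxan-4-yl in place of cyclopropyl on an aromatic carbon. In words, oxan-4-yl stands in place of cyclopropyl on an aromatic carbon.

Within the data shown here, only one measured step bears on this change. Replacing methoxy with cyclopropyl on that same carbon gave a 1.2-fold higher number from compound 1 to compound 2 (0.06 log units; within the scatter), a step within the scatter. Among the measured compounds shown here, that is thin evidence, since no measured compound yet carries oxan-4-yl. Still, it offers no reason to expect a large move in this assay, in either direction.

The estimated step is a 1.3-fold lower number from compound 2 to compound 3 (0.10 log units; within the scatter), which means no change beyond the scatter is expected. For compound 3 the expected value is 23 nm/s, with an estimated range from 11 nm/s to 45 nm/s.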

Compound 3, apparent permeability: 27 nm/s
Compound 3: middle estimate off by 1.2-fold (0.07 log units), on the low side; the range from low to high includes it.
By their numbers in this assay, from the lowest: compounds 1, 3 and 2 (each within the scatter of the next).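

In this assay, this position on an aromatic carbon, next to the ring nitrogen, now carries oxan-4-yl, a six-membered non-aromatic ring with 1 hetero atom and a hydrogen-bond acceptor that cyclopropyl lacks, and the step is a 1.1-fold lower number from compound 2 to compound 3 (0.03 log units; within the scatter), within the scatter. Set against the methoxy compound, the same group gives a 1.1-fold higher number from compound 1 to compound 3 (0.03 log units; within the scatter), also within the scatter, so methoxy, cyclopropyl and oxan-4-yl cannot be told apart on this read-out, even though they differ in ring, in heavy-atom count and in acceptor count. No information is available on why these three groups give such closely matched numbers.

The compounds shown leave open whether a group of a different kind on this carbon, such as an amine, a carboxylic acid or a longer carbon chain, would give a number beyond the scatter from these three. They also leave open whether the same swaps would stay within the scatter if another part of the shared core were changed at the same time.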